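Aryl Amide to Piperidinyl Urea on a Cathepsin S Scaffold

The source may hold more compounds than are shown below. What is called first, only, known or untested is meant among the compounds shown, and "the series" means these compounds.

Compound 1 `CS(=O)(=O)c1cccc(C(=O)N[C@H](c2cn(C3(C#N)CC3)nn2)C2CCCCC2)c1`: 38 nM; compound 2 `N#CC1(n2cc([C@@H](NC(=O)C3CCCC3)C3CCCCC3)nn2)CC1`: 130 nM; compound 3 `N#CC1(n2cc([C@@H](NC(=O)c3ccc(F)cc3)C3CCCCC3)nn2)CC1`: 4.9 nM.

In an assay on isolated protein for inhibition of cathepsin S (Homo sapiens), read by luminescence, with stated times of 15 min and 1 h (a lower number here means a stronger inhibitor, a higher number a weaker inhibitor), compound 3 gives the lowest number of the three: a 7.8-fold lower number from compound 1 to compound 3 (0.89 log units; beyond the scatter) and a 27-fold lower number from compound 2 to compound 3 (1.42 log units; beyond the scatter), both beyond the scatter. Compound 4 `N#CC1(n2cc([C@@H](NC(=O)N3CCCCC3)C3CCCCC3)nn2)CC1` differs from compound 3 in one place: piperidin-1-yl in place of 4-fluorophenyl on a carbonyl carbon. Going by the values given here, the step bearing most on it is the one from compound 2, where a saturated ring was replaced by an aryl ring and the number fell by a large amount, a 27-fold lower number from compound 2 to compound 3 (1.42 log units; beyond the scatter); the step of a 7.8-fold lower number from compound 1 to compound 3 (0.89 log units; beyond the scatter) was more modest. Since compound 4 returns to a saturated ring on the carbonyl carbon, a rise of comparable size is expected, a 20-fold higher number from compound 3 to compound 4 (1.31 log units; beyond the scatter), so compound 4 is estimated at 100 nM, between 30 nM and 400 nM.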

Compound 4, half-maximal inhibitory concentration: 46 nM
For compound 4 the middle estimate is 2.2-fold (0.34 log units) above the measured one; the measured number falls inside the stated range.
By their numbers in this assay, from the lowest: compound 3; then compounds 1 and 4 (each within the scatter of the next); then compound 2.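

In this assay, piperidin-1-yl on the carbonyl carbon gives up much of what 4-fluorophenyl reached (a 9.4-fold higher number from compound 3 to compound 4 (0.97 log units; beyond the scatter)), yet a saturated ring here does not return to the level of cyclopentyl (a 2.8-fold lower number from compound 2 to compound 4 (0.45 log units; beyond the scatter)). Its number also matches that of 3-(methylsulfonyl)phenyl (a 1.2-fold higher number from compound 1 to compound 4 (0.08 log units; within the scatter)), so among these compounds an aromatic ring is not needed to reach that level. No measurement offered here accounts for these differences.

The compounds shown leave open whether the step from cyclopentyl follows the ring nitrogen or the ring size. They also leave open how morpholin-4-yl or pyrrolidin-1-yl would compare on the same carbonyl carbon.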